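This account rests on a few compounds, and the source may have more. Where it says the series, first, only, none or still open, it means among the compounds named here.

Compound 1, `COc1ccc(CNc2ccnc(N3CCN(C)CC3)n2)cc1`, gives > 200000 nM in a functional assay on MCF7 cells (Homo sapiens) for cytotoxicity, read by MTT assay, with a stated time of 48 h (a higher number here means a weaker inhibitor, a lower number a stronger inhibitor), which is a limit of the assay.
Compound 2, `COc1ccc(Nc2nccc(N3CCN(C)CC3)n2)cc1`, gives > 200000 nM in this assay, again a limit rather than a number.

Compound 2 thus stands at the edge of what this assay can report: its value is a limit, and the same holds for compound 1, so both values sit at the limit of > 200000 nM in this assay, at which 2 of the 2 values shown sit. Among the compounds with values here, no step between measured compounds can be computed from such limits.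

Compound 3, `CN1CCN(c2ccnc(Nc3ccc(Cl)cc3)n2)CC1`, differs from compound 2 by chloro in place of methoxy on an aromatic carbon of a six-membered aromatic ring of carbon only, para to a large group. With both measured values being limits, nothing measured guides the size of this change; the expected step that the limit leaves unreadable from compound 2 to compound 3 is none beyond the scatter, with compound 3 most likely reported again only as a limit. Compound 3 is therefore estimated at 250000 nM, with a range from 60000 nM to 1000000 nM.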

Compound 3, half-maximal inhibitory concentration: > 200000 nM
Compound 3: no number, only a limit; the forecaster's own chance of this, stated with the estimate: 80%; the middle value does not contradict the limit.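

In this assay, within the data shown here, compound 3 gives > 200000 nM, again a limit and not a number, so no step from compound 2 to compound 3 can be read: the limit of > 200000 nM in this assay, at which 3 of the 3 values shown sit. The compounds shown leave open what change to the shared core, if any, would yield a measurable number in this assay.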